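The compounds below may be only part of what the source reports. "The series", "measured", "known", "first", "only" and "open" are said of these compounds alone.

Measured compounds:
compound 1 `COc1ccc(C2CC(Nc3nc4ccc(C)cc4s3)=NN2C(C)=O)cc1`: 37.3 umol/kg
compound 2 `CC(=O)N1N=C(Nc2nc3ccc(C)cc3s2)CC1OC1=CC=C1`: 160 umol/kg
compound 3 `CC(=O)N1N=C(Nc2nc3ccccc3s2)CC1OC1=CC=C1`: 382 umol/kg

All three were tested in a functional assay on the whole organism (Hindlimb, strain albino) with Mus musculus as the target, in the maximal electroshock model, with a stated time of 0.5 h; on this read-out lower numbers stand for an effect already at smaller amounts and higher numbers for an effect only at larger amounts of compound. Compound 4 `COc1ccc(C2CC(Nc3nc4ccccc4s3)=NN2C(C)=O)cc1` has not yet been measured there. It is reached from compound 3 by the change (a group of 8 heavy atoms (7 carbon, 1 oxygen; one six-membered aromatic ring of carbon only) in place of a group of 5 heavy atoms (4 carbon, 1 oxygen; one four-membered non-aromatic ring of carbon only), on a saturated ring carbon), the same change that leads from compound 2 to compound 1, (a group of 8 heavy atoms (7 carbon, 1 oxygen; one six-membered aromatic ring of carbon only) in place of a group of 5 heavy atoms (4 carbon, 1 oxygen; one four-membered non-aromatic ring of carbon only), on a saturated ring carbon); the two cores differ by hydrogen in place of methyl on an aromatic carbon. That change made a step of a 4.3-fold lower number from compound 2 to compound 1 (0.63 log units; beyond the scatter), while the core difference alone gave a 2.4-fold higher number from compound 2 to compound 3 (0.38 log units; beyond the scatter). Since the two changes occur at the same place, a step of similar size is expected from compound 3 to compound 4, a 4.2-fold lower number from compound 3 to compound 4 (0.63 log units; beyond the scatter), resting on the step seen from compound 2 to compound 1. Compound 4 is therefore estimated at 90 umol/kg.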

Compound 4, dose for half-maximal effect: 226 umol/kg
Beside the measured number, compound 4's estimate is 2.5-fold (0.40 log units) below it, and the stated range ends below it.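

In this assay, 4-methoxyphenyl in place of the four-membered ring group on the saturated ring carbon gave a 1.7-fold lower number from compound 3 to compound 4 (0.23 log units; within the scatter), which can be set against the earlier step on the methyl-bearing core: the same change on two cores in this assay, a 4.3-fold lower number (0.63 log units; beyond the scatter) from compound 2 to compound 1 and a 1.7-fold lower number (0.23 log units; within the scatter) from compound 3 to compound 4, 2.5-fold (0.40 log units) apart, within the scatter of two such steps. Hydrogen in place of methyl on an aromatic carbon gave a 6.1-fold higher number from compound 1 to compound 4 (0.78 log units; beyond the scatter), which can likewise be set against its earlier counterpart: the same change on two cores in this assay, a 2.4-fold higher number (0.38 log units; beyond the scatter) from compound 2 to compound 3 and a 6.1-fold higher number (0.78 log units; beyond the scatter) from compound 1 to compound 4, 2.5-fold (0.40 log units) apart, within the scatter of two such steps. Read together, these pairs give no sign that either step depends on the other change, but they cannot show that the steps are equal, and the new step from the group swap stays within the scatter on its own.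

The compounds shown leave open how a chloro group would compare with methyl on the aromatic carbon. They also leave open whether an amine on the saturated ring carbon would fit the same picture.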